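Benzyloxy series: exchanging the arm on the aniline nitrogen

The source may hold more compounds than are shown below. What is called first, only, known or untested is meant among the compounds shown, and "the series" means these compounds.

Measured in a functional assay on CHOK cells for antagonist activity at growth hormone secretagogue receptor type 1 (Homo sapiens), read by calcium flux; on this read-out lower numbers stand for stronger inhibition and higher numbers for weaker inhibition:
compound 1, `CCc1nc(N)nc(N)c1-c1ccc(NCc2ccc([N+](=O)[O-])cc2)cc1`: 23 nM
compound 2, `Nc1nc(N)c(-c2ccc(NCc3ccc([N+](=O)[O-])cc3)cc2)c(COCc2ccccc2)n1`: 5.8 nM

Compound 2 stands lowest of the two numbers. Within the data shown here, the one step in hand, a 4.0-fold lower number from compound 1 to compound 2 (0.60 log units; beyond the scatter), lies beyond the scatter and concerns the substituent on a saturated chain carbon bound to an aromatic carbon of the shared core.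

Compound 3, `Nc1nc(N)c(-c2ccc(NCc3csc(Cl)c3)cc2)c(COCc2ccccc2)n1`, keeps the benzyloxy group of compound 2 and alters the other end of the molecule: 5-chlorothiophen-3-yl in place of 4-nitrophenyl on a saturated chain carbon bound to a nitrogen on an aromatic ring. Among the measured compounds shown here, no measured pair in this assay differs at that place, so nothing in the data shows how the number moves when 4-nitrophenyl is exchanged for 5-chlorothiophen-3-yl. For the measured compounds named here, the only step available, from compound 1 to compound 2, sits at a different position and cannot be carried over. Going by the values given here, with no precedent, the expectation for compound 3 is a step of a 1.4-fold higher number from compound 2 to compound 3 (0.14 log units; within the scatter) that stays within the scatter, with a wide band on either side. The estimate for compound 3 is 8 nM, bounded by 2 nM and 30 nM.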

Compound 3, half-maximal inhibitory concentration: 170 nM
The estimate for compound 3 lay 21-fold (1.33 log units) below the measured number; measured number above the stated range.
By their numbers in this assay, from the lowest: compound 2; then compound 1; then compound 3.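

In this assay, among these compounds, this is the first reading at the place on a saturated chain carbon bound to a nitrogen on an aromatic ring, and the exchange of 4-nitrophenyl for 5-chlorothiophen-3-yl gives a 29-fold higher number from compound 2 to compound 3 (1.47 log units; beyond the scatter) as a large step toward weaker inhibition, so the group at this place is far from interchangeable. This step is also greater than a 4.0-fold lower number from compound 1 to compound 2 (0.60 log units; beyond the scatter) at the only other place changed so far, which makes the arm on the nitrogen the more sensitive of the two places on the evidence of these compounds. Nothing measured here offers an explanation for the size of the step.

The exchange replaces a six-membered aromatic ring of carbon only with a five-membered aromatic ring with one hetero atom and also swaps the nitro group for chlorine, so this single step cannot show which part of the change carries the shift; a 4-chlorophenyl group at the same place would separate the two. Also open, going by these compounds, is whether the same exchange gives a step of similar size on the core of compound 1, which carries the ethyl group instead of the benzyloxy arm.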